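Thiophen-2-yl to furan-3-yl: compound 2 to compound 4

The source may hold more compounds than are shown below. What is called first, only, known or untested is meant among the compounds shown, and "the series" means these compounds.

In a functional assay on KB 3-1 cells (Homo sapiens) for cytotoxicity, read by MTT assay, with a stated time of 68 h (a higher number here means a weaker inhibitor, a lower number a stronger inhibitor), compound 1 `O=C(Nc1cccc(-c2ccccc2C(F)(F)F)c1)C(Cl)Cl` gives 35900 nM and compound 3 `O=C(Nc1cc(-c2ccc(OC3CCCCO3)cc2)cc(-c2ccc(OC3CCCCO3)cc2)c1)C(Cl)Cl` gives 7220 nM. Compound 2 `O=C(Nc1cccc(-c2cccs2)c1)C(Cl)Cl` gives no number, only a limit of the assay, > 50000 nM.

Compound 4 `O=C(Nc1cccc(-c2ccoc2)c1)C(Cl)Cl` carries furan-3-yl in place of thiophen-2-yl on an aromatic carbon. Going by the values given here, no pair of measured compounds differs in a single place, so the size of this change in this assay cannot be read from the series. No step beyond the scatter is expected, and a reading at the limit would not be a surprise. The estimated step is an at least 1.1-fold lower number from compound 2 to compound 4 (0.04 log units; that floor lies within the scatter). Compound 4 is expected at 45000 nM, with an estimated range of 20000 nM to 70000 nM.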

Compound 4, half-maximal inhibitory concentration: > 50000 nM
Compound 4: no number, only a limit; the forecaster's own chance of this, stated with the estimate: 60%; middle value at least 1.1-fold (0.04 log units) away from the limit.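

In this assay, going by these compounds alone, compound 2 and compound 4 each give only a limit, so no step between them can be read. From the compounds shown here alone, whether furan-3-yl in place of thiophen-2-yl changes the value at all stays open.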